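A Bromo Replacement on a Narrow Range of Values

This account rests on a few compounds, and the source may have more. Where it says the series, first, only, none or still open, it means among the compounds named here.

Going by the values given here, in a functional assay on A549 cells (Homo sapiens) for antiproliferative activity, read by MTT assay, with a stated time of 48 h (a lower number here means a stronger inhibitor, a higher number a weaker inhibitor), compound 1 `c1ccc(-c2nnc(-c3cn4ccccc4n3)o2)cc1` gives 23400 nM and compound 2 `COc1ccc(-c2nnc(-c3cn4ccccc4n3)o2)cc1` gives 11900 nM, so compound 2 stands within the scatter of the only other compound measured. Compound 3 `Brc1ccc(-c2nnc(-c3cn4ccccc4n3)o2)cc1` has bromo in place of methoxy on an aromatic carbon. Among the compounds with values here, the one measured change at this carbon, a 2.0-fold lower number from compound 1 to compound 2 (0.29 log units; within the scatter), gives no sign of a large effect, so no step beyond the scatter is expected in this assay. The estimated change is a 1.2-fold higher number from compound 2 to compound 3 (0.07 log units; within the scatter). Compound 3 is expected at about 14000 nM, within an estimated range of 6000 nM to 32000 nM.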

Compound 3, half-maximal inhibitory concentration: > 50000 nM
Compound 3: only a limit was reported; the forecaster's own chance of this, stated with the estimate: 5%; middle value at least 3.5-fold (0.55 log units) away from the limit.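

This carbon, para to a large group, proves sensitive to what it carries: bromo in place of methoxy gives an at least 4.2-fold higher number from compound 2 to compound 3 (0.62 log units; beyond the scatter) and bromo in place of hydrogen gives an at least 2.1-fold higher number from compound 1 to compound 3 (0.32 log units; beyond the scatter). Going by these compounds alone, the earlier step at this carbon stayed within the scatter, so these are the first changes here that lie beyond it. Both steps are bounds and not sizes, as compound 3 carries only a limit in this assay: the limit of > 50000 nM in this assay, at which 1 of the 3 values shown sits.

The compounds shown leave open how far compound 3 lies past that limit. They also leave open whether chloro, an amine or a carboxylic acid at this carbon would stay with compounds 1 and 2 or move as bromo does.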